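A Second Fluorine on the Benzyl Amine Series

The source may report more compounds than this note shows. Statements on the series, on what has been measured and on what is new or still open speak of the compounds shown alone.

Measured in a functional assay on HCT-116 cells (Homo sapiens) for antiproliferative activity, read by WST assay, with a stated time of 72 h; a higher number here means a weaker inhibitor of growth, a lower number a stronger inhibitor of growth:
Compound 1 `O=C(NO)c1cnc(N2C[C@@H]3[C@H](C2)[C@H]3NCc2ccccc2)nc1`: 120 nM
Compound 2 `O=C(NO)c1cnc(N2C[C@@H]3[C@H](C2)[C@H]3NCC2CCCCC2)nc1`: 160 nM
Compound 3 `O=C(NO)c1cnc(N2C[C@@H]3[C@H](C2)[C@H]3NCc2ccc(F)cc2)nc1`: 380 nM

In this assay compound 3 stands highest of the three at 380 nM, making it the weakest inhibitor of growth so far. Compound 4 `O=C(NO)c1cnc(N2C[C@@H]3[C@H](C2)[C@H]3NCc2cc(F)cc(F)c2)nc1` has 3,5-difluorophenyl in place of 4-fluorophenyl on a saturated chain carbon bound to an amine nitrogen. For the measured compounds named here, no measured compound carries this group, so the evidence is indirect. The closest step is the addition of fluoro to the phenyl group, which gave a 3.2-fold higher number from compound 1 to compound 3 (0.50 log units; beyond the scatter). The exchange of cyclohexyl for 4-fluorophenyl gave a 2.4-fold higher number from compound 2 to compound 3 (0.38 log units; beyond the scatter), while the exchange of phenyl for cyclohexyl gave a 1.3-fold higher number from compound 1 to compound 2 (0.12 log units; within the scatter), so this position has so far produced only modest steps. Since compound 4 keeps a fluorinated phenyl group, only a small upward move within the scatter is expected, an estimated 1.2-fold higher number from compound 3 to compound 4 (0.07 log units; within the scatter). For compound 4 the estimated value is 450 nM, with an expected range of 180 nM to 1100 nM.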

Compound 4, concentration for 50% growth inhibition: 200 nM
Beside the measured number, compound 4's estimate is 2.3-fold (0.35 log units) above it, within the range that was stated.
By their numbers in this assay, from the lowest: compounds 1, 2, 4 and 3 (each within the scatter of the next, the first and the last beyond it).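

In this assay the exchange of 4-fluorophenyl for 3,5-difluorophenyl gives a 1.9-fold lower number from compound 3 to compound 4 (0.28 log units; within the scatter) and so does not extend the earlier upward step seen with fluoro. Unlike compound 3, compound 4 stays within the scatter of both unfluorinated partners, with a 1.7-fold higher number from compound 1 to compound 4 (0.22 log units; within the scatter) and a 1.3-fold higher number from compound 2 to compound 4 (0.10 log units; within the scatter) as its steps, so among these compounds a fluorinated phenyl at this place does not by itself bring a step beyond the scatter. No measurement shown here explains this result.

The compounds shown leave open whether 3-fluorophenyl would read like compound 3 or like compound 4, which would help separate the number of fluorines from their placement. They also leave open how chlorophenyl, methoxyphenyl or a pyridylmethyl group would compare on the same saturated chain carbon bound to an amine nitrogen.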